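Moving the Chlorine on a Chloroacetamide Chalcone

The source may hold more compounds than are shown below. What is called first, only, known or untested is meant among the compounds shown, and "the series" means these compounds.

Measured in a functional assay on SMMC-7721 cells (Homo sapiens) for cytotoxicity, read by MTT assay, with a stated time of 72 h; a higher number here means a weaker inhibitor, a lower number a stronger inhibitor:
- Compound 1 `O=C(CSC(=S)N[C@H]1CCOC1=O)Nc1ccc(Cl)cc1`: > 128000 nM, a limit
- Compound 2 `O=C(CSC(=S)N[C@H]1CCOC1=O)Nc1ccc(O)cc1`: > 128000 nM, a limit
- Compound 3 `O=C(CCl)Nc1ccc(C(=O)/C=C/c2ccc(Cl)cc2)cc1`: 8160 nM

Of these three compounds, only compound 3 has a true number in this assay, at 8160 nM. Compound 1 and compound 2 both rest on (the limit of > 128000 nM in this assay, at which 2 of the 3 values shown sit), and neither gives a number.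

The next compound is compound 4 `O=C(CCl)Nc1ccc(C(=O)/C=C/c2ccccc2Cl)cc1`, which has the same atoms as compound 3, joined differently: 2-chlorophenyl in place of 4-chlorophenyl on a double-bonded chain carbon bound to a double-bonded chain carbon. A 2-chlorophenyl stands in place of 4-chlorophenyl on a double-bonded chain carbon bound to a double-bonded chain carbon.

For the measured compounds named here, only one measured step exists, a step that the two limits leave unreadable from compound 1 to compound 2. It also concerns a group on an aromatic carbon, but it has no readable size, and it belongs to compounds with a different core from compound 3. Going by the values given here, it therefore offers no measure for this change, and no measured step shows what the new chlorine arrangement does. The value of compound 3 at 8160 nM remains the only anchor, so no shift beyond the usual scatter is expected in this assay, in either direction. The estimated change is a 1.1-fold higher number from compound 3 to compound 4 (0.04 log units; within the scatter). The expected value for compound 4 is 9000 nM, with an estimated range from 3000 nM to 27000 nM.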

Compound 4, half-maximal inhibitory concentration: 11100 nM
Estimate against measurement, compound 4: 1.2-fold (0.09 log units) below; the measured number falls inside the stated range.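

In this assay, for the compounds shown here, the change gives the first readable step in this set, a 1.4-fold higher number from compound 3 to compound 4 (0.13 log units; within the scatter), so 2-chlorophenyl and 4-chlorophenyl on a double-bonded chain carbon bound to a double-bonded chain carbon cannot be told apart here. Going by these compounds alone, the earlier compounds could not show this, since their only step was unreadable and belonged to a different core, with no number on either side: the limit of > 128000 nM in this assay, at which 2 of the 4 values shown sit. The two chlorophenyl groups have the same heavy atoms and the same counts of donors and acceptors, and nothing shown here gives a reason for the result or ties it to any property of either group.

This single pair speaks only to these two chlorine arrangements, and it cannot say whether the position matters once a different group sits on the phenyl ring, such as an amine, a carboxylic acid or a methoxy group. Also open, going by these compounds, is whether the number would stay within the scatter if a longer chain took the place of the chloroacetamide part shared by compound 3 and compound 4.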